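A few compounds are considered here, and "the series" means these few. Any claim that something is new, unique, unknown or untested is made for them only; others in the source may bear on it.

Measured so far in a functional assay on HT-29 cells (Homo sapiens) for cytotoxicity, read by MTT assay, with a stated time of 72 h (a lower number here means a stronger inhibitor, a higher number a weaker inhibitor), are three compounds
compound 1 `COc1ccc(-c2c(-c3cc(Cl)c(OC)c(OC)c3)ncn2C)cc1F` gives 530 nM
compound 2 `COc1cc(-c2ncn(C)c2-c2ccc(N(C)C)cc2)cc(Cl)c1OC` gives 0.2 nM
compound 3 `COc1ccc(-c2c(-c3cc(Br)c(OC)c(OC)c3)ncn2C)cc1N` gives 0.02 nM

Compound 1 holds the highest number of the three, and compound 2 and compound 3 both lie lower by far more than the usual scatter. The next compound to be measured is compound 4 (`COc1ccc(-c2c(-c3cc(Br)c(OC)c(OC)c3)ncn2C)cc1F`), which differs from compound 1 in one place. The change is bromo in place of chloro on an aromatic carbon on an aromatic carbon of a six-membered aromatic ring of carbon only, ortho to a methoxy group.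

Among the measured compounds shown here, no measured pair shows this exchange alone, so the evidence for it is indirect. Compound 3 carries the bromo and gives 0.02 nM in this assay while compound 2 carries the chloro and gives 0.2 nM there, but both also differ from compound 4 elsewhere. Neither value can therefore be read as the effect of the halogen. The expected change in this assay is a moderate one toward a lower number, estimated as a 3.5-fold lower number from compound 1 to compound 4 (0.55 log units; beyond the scatter) at this stage. Compound 4 is expected at 150 nM with an estimated range from 20 nM to 800 nM once measured.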

Compound 4, half-maximal inhibitory concentration: 510 nM
Compound 4: the middle estimate sits 3.4-fold (0.53 log units) below what was measured; low and high end bracket the measured number.
By their numbers in this assay, from the lowest: compound 3; then compound 2; then compounds 4 and 1 (each within the scatter of the next).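

In this assay, bromo in place of chloro on this aromatic carbon, ortho to a methoxy group, gives a 1.0-fold lower number from compound 1 to compound 4 (0.02 log units; within the scatter), so with the fluoro group present the two halogens cannot be told apart at this position. The large change appears instead with fluoro in place of amino on the other aromatic ring, which gives a 26000-fold higher number from compound 3 to compound 4 (4.41 log units; beyond the scatter); between these two compounds, the very low number of compound 3 therefore goes with the amino group and not with the bromo, which both carry. Nothing measured here explains either step.

The compounds shown leave open whether bromo and chloro would also match when an amino group stands in place of the fluoro, and how an iodo or a methyl group would read at the halogen position. Also open, on these data alone, is how a hydroxyl or a methylamino group would read in place of the amino group of compound 3, and so whether the low number is particular to the amino group itself.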